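The source may report more compounds than this note shows. Statements on the series, on what has been measured and on what is new or still open speak of the compounds shown alone.

In an assay on isolated protein for inhibition of phosphodiesterase 4A (Sus scrofa) (on this read-out higher numbers stand for weaker inhibition and lower numbers for stronger inhibition), compound 1 `COc1ccc(C(=O)Nc2ccccc2F)cc1OC1CCCC1` gives 10700 nM, while compound 2 `COc1ccc(C(=O)Nc2ccccc2C(=O)c2ccccc2)cc1OC1CCCC1` gives 1700 nM; the difference between them is a 6.3-fold lower number from compound 1 to compound 2 (0.80 log units; beyond the scatter). Compound 3 `COc1ccc(C(=O)Nc2ccccc2Cl)cc1OC` gives 650 nM in this assay, the lowest of the three numbers; its nearest neighbour is compound 2, and compound 1 stands furthest away. Compound 4 `COc1ccc(C(=O)Nc2ccccc2Cl)cc1OC(=O)c1ccccc1` has not been measured yet. It differs from compound 3 by benzoyl in place of methyl on an oxygen on an aromatic ring, so that a methoxy group of the shared core becomes a benzoyloxy group. Within the data shown here, only one measured step places a benzoyl group onto a compound, namely a 6.3-fold lower number from compound 1 to compound 2 (0.80 log units; beyond the scatter), and there the benzoyl entered on an aromatic carbon in place of fluoro, not on an oxygen in place of methyl, so it bears on the present step only loosely. Among the measured compounds shown here, no measured pair shows what exchanging a methyl for a larger group on this oxygen does. The expectation for compound 4 is therefore an uncertain one: a modest shift in this assay, a 2.3-fold higher number from compound 3 to compound 4 (0.36 log units; beyond the scatter), is expected, with a higher number somewhat more likely than a lower one. Compound 4 is estimated at 1500 nM, within a range from 300 nM to 8000 nM.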

Compound 4, half-maximal inhibitory concentration: > 1000000 nM
Compound 4 gave a limit, no number (the forecaster's own chance of this, stated with the estimate: 10%); middle value at least 660-fold (2.82 log units) from the limit.
By their numbers in this assay, from the lowest: compound 3; then compound 2; then compound 1. At a limit, above all of these: compound 4.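

Among these compounds, this is the first measured change on this oxygen, and it is a drastic one: in this assay, exchanging methoxy for benzoyloxy brings an at least 1500-fold higher number from compound 3 to compound 4 (3.18 log units; beyond the scatter). A benzoyl group therefore does not act the same way everywhere, since on an aromatic carbon in place of fluoro it came with a 6.3-fold lower number from compound 1 to compound 2 (0.80 log units; beyond the scatter), whereas on this oxygen in place of methyl the number moves in the opposite direction, although these two steps start from different compounds. Compound 4 gives a limit and not a number, so its step fixes only a minimum size: the limit of > 1000000 nM in this assay, at which 1 of the 4 values shown sits.

Still open, going by these compounds, is whether this loss of inhibition belongs to benzoyl in particular or follows from almost any larger group on this oxygen; an ethyl or acetyl group there, or a benzyl group, which keeps the aromatic ring but has no carbonyl, could separate these possibilities. Also open, on these data alone, is whether benzoyl on this oxygen has a similar effect in a compound carrying fluoro in place of chloro.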